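Swapping a methyl on an aromatic oxygen

The compounds below may be only part of what the source reports. "The series", "measured", "known", "first", "only" and "open" are said of these compounds alone.

Going by the values given here, in a functional assay on BMEC cells (Bos taurus) for antiproliferative activity (a higher number here means a weaker inhibitor, a lower number a stronger inhibitor), compound 2 `COc1cc(/C=C\Cc2cc(OC)c3ccsc3c2)cc(OC)c1OC` gives 8100 nM, the higher of the two numbers so far, while compound 1 `COc1cc(/C=C\Cc2cc(O)c3ccsc3c2)cc(OC)c1OC` gives 87 nM. The two differ in one place, with a methyl in place of hydrogen on an oxygen on an aromatic ring. That single change produces a 93-fold higher number from compound 1 to compound 2 (1.97 log units; beyond the scatter), a large step.

Compound 3 `COc1cc(/C=C\Cc2cc(OP(=O)(O)O)c3ccsc3c2)cc(OC)c1OC` loses that same methyl, and the change is a group of 4 heavy atoms (3 oxygen, 1 phosphorus; no ring) in place of one carbon atom, on an oxygen on an aromatic ring, on an oxygen on an aromatic ring. Among the compounds with values here, no measured step covers this new group, so the methyl step is the only guide, and it shows how strongly this oxygen can move the number. A large fall is therefore expected, though probably not all the way to the value of compound 1. The expected change is a 32-fold lower number from compound 2 to compound 3 (1.51 log units; beyond the scatter). Compound 3 is estimated at 250 nM, with an expected range from 60 nM to 2500 nM.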

Compound 3, half-maximal inhibitory concentration: 640 nM
Estimate against measurement, compound 3: 2.6-fold (0.41 log units) below; measured number inside the range.
By their numbers in this assay, from the lowest: compound 1; then compound 3; then compound 2.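

In this assay, the group of 3 oxygen and 1 phosphorus atoms recovers much of what the methyl cost, with a 13-fold lower number from compound 2 to compound 3 (1.10 log units; beyond the scatter), but it does not fully match plain hydrogen on this oxygen, with a 7.4-fold higher number from compound 1 to compound 3 (0.87 log units; beyond the scatter). The oxygen on the aromatic ring therefore tolerates more than one kind of group, and the three groups seen so far give clearly different numbers, with hydrogen lowest, the new group in the middle and methyl highest. Nothing available here explains this order.

The compounds shown leave open where other groups on this oxygen would fall, such as an ethyl or an acetyl. They also leave open whether a carboxylic acid joined through a short chain here would give a number closer to compound 1 or to compound 2.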